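A few compounds are considered here, and "the series" means these few. Any claim that something is new, unique, unknown or untested is made for them only; others in the source may bear on it.

Measured so far in a functional assay on MCF7 cells (Homo sapiens) for inhibition, read by MTT assay, with a stated time of 48 h; a higher number here means a weaker inhibitor, a lower number a stronger inhibitor:

- compound 1 `CN1CCN(c2ccc(-c3c(C#N)c(-c4ccc(Cl)cc4)nc4c3c(-c3ccccc3)nn4-c3ccccc3)cc2)CC1`: 2710 nM
- compound 2 `COc1ccc(-c2nc3c(c(-c4ccccc4)nn3-c3ccccc3)c(-c3ccc(N4CCN(C)CC4)cc3)c2C#N)cc1`: 2650 nM

Compound 2 stands level with compound 1, the two numbers lying within the scatter of each other. Compound 3 `CN1CCN(c2ccc(-c3c(C#N)c(-c4ccccc4)nc4c3c(-c3ccccc3)nn4-c3ccccc3)cc2)CC1` differs from compound 2 in one place (hydrogen in place of methoxy on an aromatic carbon) with hydrogen in place of methoxy on an aromatic carbon, turning 4-methoxyphenyl into phenyl. Within the data shown here, one measured step bears on this, a swap at the same place of methoxy in place of chloro: a 1.0-fold lower number from compound 1 to compound 2 (0.01 log units; within the scatter) and so no real shift. In this assay the expected step is therefore also small, estimated as a 1.0-fold higher number from compound 2 to compound 3 (0.01 log units; within the scatter) and not expected to exceed the scatter. For compound 3 the estimated value is 2700 nM (expected range 1300 nM to 5500 nM).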

Compound 3, half-maximal inhibitory concentration: 14300 nM
Beside the measured number, compound 3's estimate is 5.3-fold (0.72 log units) below it; the measured number lies above the stated range.
By their numbers in this assay, from the lowest: compounds 2 and 1 (each within the scatter of the next); then compound 3.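

In this assay, the bare phenyl of compound 3 turns out clearly weaker than either substituted ring: a 5.4-fold higher number from compound 2 to compound 3 (0.73 log units; beyond the scatter) and a 5.3-fold higher number from compound 1 to compound 3 (0.72 log units; beyond the scatter). So this place on the ring is not indifferent after all. Methoxy and chloro read level with each other, and only hydrogen, of the three groups shown, gives the higher number. No measurement at hand explains this difference. As far as these compounds go, whether a hydroxyl, an amine or a longer chain such as ethoxy at this place would match methoxy and chloro remains open.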